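The source may hold more compounds than are shown below. What is called first, only, known or untested is meant among the compounds shown, and "the series" means these compounds.

In a functional assay on PC-3 cells (Homo sapiens) for cytotoxicity, read by MTT assay, with a stated time of 72 h (on this read-out higher numbers stand for weaker inhibition and lower numbers for stronger inhibition), compound 1 `COc1cc2ncnc(Nc3ccc(F)c(Cl)c3)c2cc1NC(=O)/C=C/c1ccc(F)cc1Cl` gives 32700 nM and compound 2 `O=C(/C=C/c1cccc(Cl)c1Cl)Nc1cc2c(Nc3ccc(F)c(Cl)c3)ncnc2cc1O[C@H]1CCOC1` gives 27500 nM. Compound 3 `O=C(/C=C/c1ccccc1[N+](=O)[O-])Nc1cc2c(Nc3ccc(F)c(Cl)c3)ncnc2cc1O[C@H]1CCOC1` gives 7760 nM, the lowest number of the three and so the strongest inhibition among them, with both other values beyond the scatter from it.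

Compound 4 `O=C(/C=C/c1ccc(F)cc1Cl)Nc1cc2c(Nc3ccc(F)c(Cl)c3)ncnc2cc1O[C@H]1CCOC1` differs from compound 3 in one group: 2-chloro-4-fluorophenyl in place of 2-nitrophenyl on a double-bonded chain carbon bound to a double-bonded chain carbon. In words, 2-chloro-4-fluorophenyl stands in place of 2-nitrophenyl on a double-bonded chain carbon bound to a double-bonded chain carbon.

Among the measured compounds shown here, no measured step shows this exact exchange, but two observations bear on it. The closest is a 3.5-fold lower number from compound 2 to compound 3 (0.55 log units; beyond the scatter), a modest step that arrives at the same 2-nitrophenyl group from a chlorine-bearing phenyl group at the same place. The incoming 2-chloro-4-fluorophenyl group also already sits in compound 1, on a differing core, at 32700 nM.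

Leaving 2-nitrophenyl for a halogen-bearing phenyl group is therefore expected to reverse a step of about that modest size, toward a higher number and weaker inhibition in this assay. The estimated change is a 3.1-fold higher number from compound 3 to compound 4 (0.49 log units; beyond the scatter). For compound 4 the expected value is 24000 nM, with an estimated range of 10000 nM to 50000 nM.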

Compound 4, half-maximal inhibitory concentration: 7150 nM
For compound 4 the middle estimate is 3.4-fold (0.53 log units) above the measured one; the whole stated range lies above it.
By their numbers in this assay, from the lowest: compounds 4 and 3 (each within the scatter of the next); then compounds 2 and 1 (each within the scatter of the next).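

In this assay, the exchange of 2-nitrophenyl for 2-chloro-4-fluorophenyl on a double-bonded chain carbon bound to a double-bonded chain carbon gives a 1.1-fold lower number from compound 3 to compound 4 (0.04 log units; within the scatter) and so leaves the two groups indistinguishable in this assay, which shows that a halogen-bearing phenyl group can match the 2-nitrophenyl group here. Halogen-bearing groups do not all read alike at this place, as replacing 2,3-dichlorophenyl with 2-chloro-4-fluorophenyl gives a 3.8-fold lower number from compound 2 to compound 4 (0.59 log units; beyond the scatter) and thus a modest gain in inhibition that goes with the choice of halogen-bearing group rather than with halogen alone. With 2-chloro-4-fluorophenyl held constant, oxolan-3-yl in place of methyl on an oxygen on an aromatic ring gives a 4.6-fold lower number from compound 1 to compound 4 (0.66 log units; beyond the scatter) as a further modest step, so the number also responds to this second place. Nothing available here offers an explanation for these steps.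

The compounds shown leave open whether an amine or a carboxylic acid on this phenyl group would hold the number at the same level. Also open, as far as these compounds go, is whether oxolan-3-yl in place of methyl would give a step of similar size with 2-nitrophenyl on the chain.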